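This account rests on a few compounds, and the source may have more. Where it says the series, first, only, none or still open, it means among the compounds named here.

Measured so far:
- compound 1 `CC1(C)[C@@H]2C[C@H]3OB([C@H](CCCCN)NC(=O)Cn4nc(CCC(=O)O)nc4Cc4ccccc4)O[C@@]3(C)[C@H]1C2` gives 7.1 nM in an assay on isolated protein for inhibition of serine protease 1 (Homo sapiens); a higher number here means a weaker inhibitor, a lower number a stronger inhibitor
- compound 2 `CC(C)(C)OC(=O)/C=C/c1nc(Cc2ccccc2)n(CC(=O)N[C@@H](CCCCN)B2O[C@@H]3C[C@@H]4C[C@@H](C4(C)C)[C@]3(C)O2)n1` gives 36 nM in this assay

Among the measured compounds shown here, compound 2 has the highest of the two numbers so far, and the one step measured so far is a 5.1-fold higher number from compound 1 to compound 2 (0.71 log units; beyond the scatter): swapping the 2-carboxyethyl for the 2-(tert-butoxycarbonyl)ethenyl group on the aromatic carbon made the inhibitor weaker.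

Compound 3 `C[S+]([O-])Cc1nc(Cc2ccccc2)n(CC(=O)N[C@@H](CCCCN)B2O[C@@H]3C[C@@H]4C[C@@H](C4(C)C)[C@]3(C)O2)n1` changes that same position again: a group of 4 heavy atoms (2 carbon, 1 oxygen, 1 sulfur; no ring) in place of a group of 9 heavy atoms (7 carbon, 2 oxygen; no ring), on an aromatic carbon. For the measured compounds named here, the group that leaves is the one whose arrival in compound 2 weakened binding, and the group that enters is smaller, without the ester and without the double bond. Going by the values given here, no measured step describes this new group directly, so the only guide is the step from compound 1 to compound 2, which shows that this position tolerates change while shifting potency by a modest amount. A modest step is therefore expected in this assay, more likely toward a lower number than a higher one, since what enters is neither of the two groups already tried; compound 3 is expected to give 18 nM, within the range 5 nM to 60 nM, corresponding to a 2.0-fold lower number from compound 2 to compound 3 (0.30 log units; within the scatter).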

Compound 3, inhibition constant: 4.8 nM
For compound 3 the middle estimate is 3.8-fold (0.57 log units) above the measured one, and the stated range ends above it.
By their numbers in this assay, from the lowest: compounds 3 and 1 (each within the scatter of the next); then compound 2.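

In this assay, the step of a 7.5-fold lower number from compound 2 to compound 3 (0.88 log units; beyond the scatter) shows that this aromatic carbon does not need a large group: the 2-(tert-butoxycarbonyl)ethenyl group can give way to a much smaller sulfur-bearing one, and the inhibitor gets stronger. The step of a 1.5-fold lower number from compound 1 to compound 3 (0.17 log units; within the scatter) stays within the scatter, so compound 1 and compound 3 cannot be told apart, even though compound 3 has no carboxylic acid; among these compounds, then, the acid of the 2-carboxyethyl group is not needed for binding at this level. No measurement shown here explains why these groups differ.

On these data alone, it remains open whether the sulfur and its oxygen matter at all, since a plain ethyl group, a methoxymethyl group, or the matching sulfone could be compared directly with compound 3. As far as these compounds go, it also remains open which part of the 2-(tert-butoxycarbonyl)ethenyl group goes with the weaker binding of compound 2, the double bond or the tert-butyl ester, a question that a saturated 2-(tert-butoxycarbonyl)ethyl group or a 2-carboxyethenyl group would separate.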